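Working notes on clearance across the shared core

The compounds below may be only part of what the source reports. "The series", "measured", "known", "first", "only" and "open" are said of these compounds alone.

Three compounds on the shared core have been run in an ADME assay (liver) for metabolic stability, with Liver microsome (Homo sapiens) as the target, using microsomes and NADPH, with a stated time of 30 min, tested at 1 uM; on this read-out higher numbers stand for fast clearance and lower numbers for slow clearance. Compound 1 `CC(C)(O)C#Cc1cc(C(O)(C(F)(F)F)C(F)(F)F)cnc1N1CCN(S(=O)(=O)c2ccc(N)nc2)CC1` carries a 3-hydroxy-3-methylbut-1-yn-1-yl group; in this assay compound 1 gives only a limit, < 14 mL.min-1.g-1. Compound 2 `Nc1ccc(S(=O)(=O)N2CCN(c3ncc(C(O)(C(F)(F)F)C(F)(F)F)cc3C#CCCO)CC2)cn1` carries a 4-hydroxybut-1-yn-1-yl group; in this assay compound 2 likewise gives only a limit, < 14 mL.min-1.g-1. Among the compounds with values here, compound 3 `CCn1cc(-c2cc(C(O)(C(F)(F)F)C(F)(F)F)cnc2N2CCN(S(=O)(=O)c3ccc(N)nc3)CC2)cn1` carries a 1-ethyl-1H-pyrazol-4-yl group and in this assay compound 3 gives 20 mL.min-1.g-1, the only number among the three; the other two values sit at the limit of < 14 mL.min-1.g-1 in this assay, at which 2 of the 3 values shown sit. The step of an at least 1.4-fold higher number from compound 1 to compound 3 (0.15 log units; that floor lies within the scatter) and the step of an at least 1.4-fold higher number from compound 2 to compound 3 (0.15 log units; that floor lies within the scatter) both have floors that lie within the scatter, and the step that the two limits leave unreadable from compound 1 to compound 2 cannot be read.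

Compound 4 `Nc1ccc(S(=O)(=O)N2CCN(c3ncc(C(O)(C(F)(F)F)C(F)(F)F)cc3-c3cnccc3F)CC2)cn1` is not yet measured. It differs from compound 3 in one place: 4-fluoropyridin-3-yl in place of 1-ethyl-1H-pyrazol-4-yl on an aromatic carbon. Within the data shown here, no measured step exchanges one aromatic group for another, so the two measured steps into compound 3 only set the scale of what a single group change has done here. No step beyond the scatter is expected; the estimated step of no change at the digits printed from compound 3 to compound 4 (within the scatter) is small, and compound 4 is expected to give 20 mL.min-1.g-1 in this assay, within 9 mL.min-1.g-1 to 45 mL.min-1.g-1.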

Compound 4, intrinsic clearance in microsomes: 17 mL.min-1.g-1
For compound 4 the middle estimate is 1.2-fold (0.07 log units) above the measured one, and the stated range covers the measured number.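

Within the data shown here, the first exchange of one aromatic group for another at this position, on an aromatic carbon ortho to a large group, gives a 1.2-fold lower number from compound 3 to compound 4 (0.07 log units; within the scatter) in this assay, so the 1-ethyl-1H-pyrazol-4-yl and 4-fluoropyridin-3-yl groups cannot be told apart on this read-out, despite the change from a five-membered to a six-membered aromatic ring. Against the two alkynyl groups only floors can be stated, with an at least 1.2-fold higher number from compound 2 to compound 4 (0.08 log units; that floor lies within the scatter) and an at least 1.2-fold higher number from compound 1 to compound 4 (0.08 log units; that floor lies within the scatter), so compound 4 adds a second aromatic comparison but no step that clears the scatter. These floors rest on limits rather than numbers, and no separation between the aromatic and alkynyl groups can be claimed: the limit of < 14 mL.min-1.g-1 in this assay, at which 2 of the 4 values shown sit.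

The compounds shown leave open how far compound 1 and compound 2 actually lie from the two aromatic compounds, since both alkynyl compounds stand only as limits. Also open, going by these compounds, is whether a pyridin-3-yl group without the fluorine, a morpholine or a carboxylic acid on this aromatic carbon would give a step beyond the scatter in this assay.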